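Ethyl to bromo on the sulfonamide's phenyl group

The source may hold more compounds than are shown below. What is called first, only, known or untested is meant among the compounds shown, and "the series" means these compounds.

Measured in a functional assay on HT-29 cells (Homo sapiens) for antiproliferative activity, read by sulforhodamine B assay, with a stated time of 48 h; on this read-out higher numbers stand for weaker inhibition and lower numbers for stronger inhibition:
Compound 1 `CCc1ccccc1NS(=O)(=O)c1ccc(N2CCNC2=O)cc1` gives 240 nM
Compound 2 `O=C1NCCN1c1ccc(S(=O)(=O)Nc2ccc(I)cc2)cc1` gives 650 nM
Compound 3 `CCc1cccc(NS(=O)(=O)c2ccc(N3CCNC3=O)cc2)c1` gives 110 nM

Compound 3 has the lowest number of the three, and both other values lie beyond the scatter from it. Compound 4 `O=C1NCCN1c1ccc(S(=O)(=O)Nc2cccc(Br)c2)cc1` differs from it by bromo in place of ethyl on an aromatic carbon, with bromo in place of ethyl on an aromatic carbon. For the measured compounds named here, no measured step makes this exchange alone. The closest evidence is a 5.9-fold lower number from compound 2 to compound 3 (0.77 log units; beyond the scatter), which also changes the substituent's place, and a 2.2-fold lower number from compound 1 to compound 3 (0.34 log units; beyond the scatter), which moves ethyl only. Both are modest. The expected step is a 1.4-fold higher number from compound 3 to compound 4 (0.13 log units; within the scatter), so little or no real change is expected in this assay. For compound 4 the estimated value is 150 nM, within an expected range of 60 nM to 400 nM.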

Compound 4, half-maximal inhibitory concentration: 77 nM
Estimate against measurement, compound 4: 1.9-fold (0.29 log units) above, within the range that was stated.
By their numbers in this assay, from the lowest: compounds 4 and 3 (each within the scatter of the next); then compound 1; then compound 2.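

In this assay, a group on the carbon meta to a large group need not be ethyl: a 1.4-fold lower number from compound 3 to compound 4 (0.15 log units; within the scatter), so bromo and ethyl cannot be told apart at this place. The 3-bromophenyl compound also keeps its distance from the other two, with an 8.4-fold lower number from compound 2 to compound 4 (0.93 log units; beyond the scatter) and a 3.1-fold lower number from compound 1 to compound 4 (0.49 log units; beyond the scatter), though each of these steps changes the group as well as its place. The pattern seen with ethyl therefore holds for one other group at this place.

Nothing available explains this match between bromo and ethyl. As far as these compounds go, whether an amine, a carboxylic acid or a longer chain would fit this place equally well remains open.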